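Cytotoxicity on Vero cells: carbamate to benzamide

A few compounds are considered here, and "the series" means these few. Any claim that something is new, unique, unknown or untested is made for them only; others in the source may bear on it.

Compound 2 `CN(C)c1cc2[nH]c(C3CCCCC3)nc2cc1NC(=O)OCc1ccccc1` is a carbamate on the shared core; compound 1 `CN(C)c1cc2[nH]c(C3CCCCC3)nc2cc1NC(=O)OCC(F)(F)F` is its trifluoroethyl counterpart. In an ADME assay on Vero cells (Chlorocebus sabaeus) for cytotoxicity, read by resazurin assay, with a stated time of 3 days (a lower number here means a stronger inhibitor, a higher number a weaker inhibitor), compound 1 gives > 100 ug/mL, a limit of the assay. In this assay compound 2 likewise gives > 100 ug/mL, also a limit. The step that the two limits leave unreadable from compound 1 to compound 2 is therefore unreadable, and the limit of > 100 ug/mL in this assay, at which 2 of the 2 values shown sit, is all the series shows. Compound 3 `CN(C)c1cc2[nH]c(C3CCCCC3)nc2cc1NC(=O)c1ccc(C(C)(C)C)cc1` differs from compound 2 by 4-(tert-butyl)phenyl in place of benzyloxy on a carbonyl carbon. For the measured compounds named here, no measured step bears readably on this change, so no direction can be drawn. Compound 3 is expected to sit at 100 ug/mL (range 40 ug/mL to 200 ug/mL), most likely again reported as a limit. The expected step is a number no higher from compound 2 to compound 3 (the limit leaves the size open).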

Compound 3, half-maximal inhibitory concentration: > 100 ug/mL
Compound 3: a limit, no number; the forecaster's own chance of this, stated with the estimate: 70%; the middle value sits exactly at the limit.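

Compound 1, compound 2 and compound 3 all end at a limit in this assay, so no new step among them can be read: the limit of > 100 ug/mL in this assay, at which 3 of the 3 values shown sit.

As far as these compounds go, whether any group on the carbonyl carbon gives a readable number in this assay stays open.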